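Bromo in place of the aminoethoxy chain on a chromone

The source may hold more compounds than are shown below. What is called first, only, known or untested is meant among the compounds shown, and "the series" means these compounds.

Measured so far:
- compound 1, `COc1cc(OC)c2c(=O)cc(-c3ccc(OC4CCNCC4)cc3)oc2c1`: "not active" (no number reported)
- compound 2, `COc1cc(OC)c2c(=O)cc(-c3ccc(OCCN)cc3)oc2c1`: 6%

Both compounds share one core and differ only in the group hanging from the phenyl ring. Among the compounds with values here, in a functional assay (Homo sapiens) for antiproliferative activity, read by resazurin assay, with a stated time of 48 h, tested at 5 uM (on this read-out lower numbers stand for a weaker effect and higher numbers for a stronger effect at the one concentration tested), compound 2 gives 6%, the only number reported here, while compound 1 is recorded without a number. Within the data shown here, compound 2 thus stands at a low level of effect, and no measured pair allows a step to be read.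

Compound 3, `COc1cc(OC)c2c(=O)cc(-c3ccc(Br)cc3)oc2c1`, has not yet been measured. It carries bromo in place of 2-aminoethoxy on an aromatic carbon. Among the measured compounds shown here, no step between measured compounds is available to anchor the change, so the expectation rests only on the low value of compound 2. For compound 3 a step of a number 4 percentage points higher from compound 2 to compound 3 (within the scatter) in this assay is expected, which would stay within the usual scatter. The estimate for compound 3 is 10%, with a range from 0% to 30%.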

Compound 3, a percentage reported as inhibition, at one concentration (the size of the read-out at that concentration, not a potency): 12%
For compound 3 the middle estimate is 2 percentage points below the measured one, and the stated range covers the measured number.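

Within the data shown here, putting bromo in place of 2-aminoethoxy on this aromatic carbon gives a number 6 percentage points higher from compound 2 to compound 3 (within the scatter) in this assay and this is the first step that can be read at this position. The chain that leaves holds a nitrogen and a hydrogen-bond donor, while the bromo that enters is a single atom with no donors or acceptors, yet this large change in the group leaves the two compounds indistinguishable on this read-out at the one concentration tested. Nothing available here explains this result.

As far as these compounds go, whether any group at this place can reach a clearly stronger effect remains open, since both compounds stand at a low level. A carboxylic acid, a nitrile or a longer chain ending in an amine could test this, and a chloro or fluoro would show whether the bromo itself matters.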